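Replacing the distal methoxyphenyl with a second acrylate ester

This account rests on a few compounds, and the source may have more. Where it says the series, first, only, none or still open, it means among the compounds named here.

Compound 1 `COC(=O)/C=C/c1cccc(N(Cc2ccc(-c3ccc(OC)cc3)cc2)C(=O)C2CCCCC2)c1` gives 89 nM in an assay on isolated protein with Bile acid receptor (Homo sapiens) as the target (a higher number here means that more compound is needed for the effect, a lower number that less compound is needed), the lowest of the two numbers shown. Compound 2 `COC(=O)/C=C/c1cccc(N(Cc2ccc(-c3ccc(OC)cc3)cc2)C(=O)C(C)C)c1` gives 97 nM, and the change a 1.1-fold higher number from compound 1 to compound 2 (0.04 log units; within the scatter) lies within the scatter. Compound 3 `COC(=O)/C=C/c1cccc(N(Cc2cccc(OC)c2)C(=O)C2CCCCC2)c1` gives only a limit of the assay, > 1000 nM, consistent with the limit of > 1000 nM in this assay, at which 1 of the 3 values shown sits. Compound 4 `COC(=O)/C=C/c1ccc(CN(C(=O)C2CCCCC2)c2cccc(/C=C/C(=O)OC)c2)cc1` differs from compound 1 in one place: 2-(methoxycarbonyl)ethenyl in place of 4-methoxyphenyl on an aromatic carbon. Among the compounds with values here, no measured step touches this position; the only measured step, on the carbonyl carbon, was small. Compound 3 carries no 4-methoxyphenyl either, and its value sits at the limit, so the distal aromatic ring seems to matter, though compound 3 also changes the benzyl substituent, so this is not a clean comparison. A higher number is expected for compound 4, by roughly a 5.6-fold higher number from compound 1 to compound 4 (0.75 log units; beyond the scatter), with a real chance that only a limit is returned. Compound 4 is therefore estimated at 500 nM, within a range of 120 nM to 2500 nM.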

Compound 4, half-maximal effective concentration: > 1000 nM
Compound 4 was reported as a limit; the forecaster's own chance of this, stated with the estimate: 30%; middle value at least 2.0-fold (0.30 log units) away from the limit.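

Exchanging 4-methoxyphenyl for 2-(methoxycarbonyl)ethenyl on this aromatic carbon, para to a large group, gives an at least 11-fold higher number from compound 1 to compound 4 (1.05 log units; beyond the scatter) and so is a large and unfavourable change at this position. Within the data shown here, compound 3 differs from compound 1 in more than one place, whereas compound 4 differs in this one place only, so this is the first clean reading of the position. The value of compound 4 is a limit and not a number, so the step sets only a lower bound on the change: the limit of > 1000 nM in this assay, at which 2 of the 4 values shown sit.

From the compounds shown here alone, it remains open whether the distal aromatic ring itself is required or whether the methoxy group contributes as well, a question that a plain phenyl would address. Going by these compounds, it is also open whether a carboxylic acid or an amine on a shorter chain at this position would fare any better than the acrylate ester.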